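The source may hold more compounds than are shown below. What is called first, only, known or untested is meant among the compounds shown, and "the series" means these compounds.

Compound 1 `CC(=O)N(C)CC#CCN1CCCC1`: 0.55 mg/kg
Compound 2 `CCOC(=O)N(C)CC#CCN1CCCC1`: > 100 mg/kg (a limit)

In a functional assay on the whole organism for agonist activity, with Mus musculus as the target (a lower number here means that less compound is needed, a higher number that more compound is needed for the effect), compound 2 stands at > 100 mg/kg, which is a limit of the assay and not a number. This is the limit of > 100 mg/kg in this assay, at which 1 of the 2 values shown sits.

Compound 3 `CN(C)C(=O)N(C)CC#CCN1CCCC1` carries dimethylamino in place of ethoxy on a carbonyl carbon. Among the compounds with values here, no measured step makes this exact swap. The one that bears on it changes the group on the same carbonyl carbon: an at least 180-fold higher number from compound 1 to compound 2 (2.25 log units; beyond the scatter). That step was large, so the group at this place clearly matters in this assay. Because of an at least 180-fold higher number from compound 1 to compound 2 (2.25 log units; beyond the scatter) a change here is expected to be able to move the number, but dimethylamino is not the methyl of compound 1, so only a partial recovery is expected. The expected change is an at least 2.5-fold lower number from compound 2 to compound 3 (0.39 log units; beyond the scatter), toward a lower number, although a result that again reaches the limit is quite possible. For compound 3 the estimate is 40 mg/kg, with an expected range of 5 mg/kg to 100 mg/kg.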

Compound 3, dose for half-maximal effect: > 10 mg/kg
Compound 3: a limit, no number (the forecaster's own chance of this, stated with the estimate: 50%); the middle value lies beyond the limit too.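

In this assay compound 3 gives > 10 mg/kg and this is a limit of the assay, not a number. Even so, the large loss seen with ethoxy now has a second example on the same carbonyl carbon, since dimethylamino in place of methyl gives an at least 18-fold higher number from compound 1 to compound 3 (1.25 log units; beyond the scatter) and so neither replacement shown keeps the low number of the methyl compound. Compound 2 and compound 3 both stand at limits, so the step between them cannot be read and the two groups cannot be ranked.

Going by these compounds, the true number for compound 3 remains unknown, and it could lie anywhere beyond its limit. Also open, on these data alone, is whether a different group on this carbonyl carbon, such as ethyl or methoxy, would stay close to compound 1 or lose as much as these two.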